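The compounds below may be only part of what the source reports. "The series", "measured", "known", "first", "only" and "open" are said of these compounds alone.

Going by the values given here, compound 2 `Cn1c(-c2ccncc2)c(C2CCCC2)c2ccc(C(=O)NC3(C(=O)Nc4ccc(/C=C/C(=O)O)cc4)CCC3)cc21` stands highest of the two numbers so far in an in vitro ADME assay on microsomes from liver (Rattus norvegicus) for metabolic stability (a lower number here means that the compound disappears faster, a higher number that the compound lasts longer), where compound 2 gives 1.15 h; the nearest neighbour is compound 1 `COc1ccc(-c2c(C3CCCC3)c3ccc(C(=O)NC4(C(=O)Nc5ccc(/C=C/C(=O)O)cc5)CCC4)cc3n2C)cn1`, which in this assay gives 1.02 h, and the two lie within the scatter of each other. Among the compounds with values here, the only measured step on the aromatic carbon of the shared core, a 1.1-fold higher number from compound 1 to compound 2 (0.05 log units; within the scatter), was within the scatter. Compound 3 `Cn1c(-c2cnccn2)c(C2CCCC2)c2ccc(C(=O)NC3(C(=O)Nc4ccc(/C=C/C(=O)O)cc4)CCC3)cc21` takes the next change at the same place: pyrazin-2-yl in place of pyridin-4-yl on an aromatic carbon. Within the data shown here, no measured pair shows a pyrazin-2-yl group, so the step from compound 2 to compound 3 can only be set against the one step that touches this position, and that step gave no movement beyond the scatter in this assay. The expectation is therefore that compound 3 holds a half-life close to that of compound 2, with a step of a 1.0-fold lower number from compound 2 to compound 3 (0.02 log units; within the scatter) expected to stay within the scatter. Compound 3 is estimated at 1.1 h in this assay, with a range from 0.6 h to 2.2 h expected to cover most repeats.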

Compound 3, half-life: 0.933 h
The estimate for compound 3 lay 1.2-fold (0.07 log units) above the measured number; the range from low to high includes it.
By their numbers in this assay, from the lowest: compounds 3, 1 and 2 (each within the scatter of the next).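

Across the aromatic carbon next to the ring nitrogen, the move to a ring with 2 hetero atoms, pyrazin-2-yl in place of pyridin-4-yl, gives in this assay a 1.2-fold lower number from compound 2 to compound 3 (0.09 log units; within the scatter). Replacing 6-methoxypyridin-3-yl with pyrazin-2-yl, a change that also removes the methoxy group, gives a 1.1-fold lower number from compound 1 to compound 3 (0.04 log units; within the scatter), so all three nitrogen-containing aromatic rings now sit within the scatter of one another and this half-life has so far shown no measurable response to the number of ring nitrogens or to the methoxy group at this position. No supporting information is available to explain this flat result.

As far as these compounds go, all three groups at this position are six-membered aromatic rings with at least one ring nitrogen, so it remains open whether a plain phenyl ring, or a non-aromatic group such as a morpholine or a basic amine, would leave the half-life in this assay equally unchanged. The cyclopentyl group and the rest of the shared core are also constant across compound 1, compound 2 and compound 3, so their contribution to the half-life cannot be judged from these compounds.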